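The compounds below may be only part of what the source reports. "The series", "measured", "known", "first", "only" and "open" are said of these compounds alone.

Measured so far:
- compound 1 `C=CCn1c(=O)n(CCCCCCCC)c2nc(N)nc(O)c21`: 130%
- compound 2 `C=CCn1c(=O)n(C2C=CC(CO)O2)c2nc(N)nc(O)c21`: 45%

In a functional assay on the whole organism (B cells) with Mus musculus as the target (on this read-out higher numbers stand for larger maximal responses and lower numbers for smaller maximal responses), compound 1 reaches 130%, whereas compound 2 gives 45%, the lower of the two numbers, a gap beyond the usual scatter. Compound 3 `C=CCn1c(=O)n(CCCCO)c2nc(N)nc(O)c21` is not yet measured. It differs from compound 2 in one place: a group of 5 heavy atoms (4 carbon, 1 oxygen; no ring) in place of a group of 7 heavy atoms (5 carbon, 2 oxygen; one five-membered non-aromatic ring with 1 hetero atom), on an aromatic nitrogen. Because compound 1 with its plain chain gives 130%, a chain in compound 3 is expected to raise the maximal response, by a step of a number 40 percentage points higher from compound 2 to compound 3 (beyond the scatter) that is estimated to lie beyond the scatter. Compound 3 is expected to give 85%, within 45% to 130%.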

Compound 3, largest response reached (reported as maximal response), in percent of the reference or control that the assay uses: 12%
For compound 3 the middle estimate is 73 percentage points above the measured one, outside the stated range (below it).
By their numbers in this assay, from the lowest: compound 3; then compound 2; then compound 1.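

In this assay, an open chain on this aromatic nitrogen does not by itself keep the response high: replacing the ring-bearing group with 4-hydroxybutyl gives a number 33 percentage points lower from compound 2 to compound 3 (beyond the scatter). What the chain carries also counts: hydroxy in place of butyl, four bonds along the chain from the aromatic nitrogen, gives a number 118 percentage points lower from compound 1 to compound 3 (beyond the scatter). Nothing measured here explains either drop. On these data alone, it remains open whether an amine in place of the hydroxy, or a hydroxy at the end of a longer chain, would bring the response back up.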